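Methyl in place of hydrogen on compound 2

This account rests on a few compounds, and the source may have more. Where it says the series, first, only, none or still open, it means among the compounds named here.

In a functional assay on HepG2 cells (Homo sapiens) for cytotoxicity, read by MTT assay, with a stated time of 48 h (on this read-out higher numbers stand for weaker inhibition and lower numbers for stronger inhibition), compound 1 (`O=C1C(Br)=C[C@H]2CO[C@@H]1O2`) gives 14000 nM and compound 2 (`O=C1C[C@H](Sc2ccccc2)[C@H]2CO[C@@H]1O2`) gives 17000 nM so the two stand within the scatter of each other. Compound 3 (`Cc1ccc(S[C@H]2CC(=O)[C@@H]3OC[C@H]2O3)cc1`) carries methyl in place of hydrogen on an aromatic carbon, para to a large group (methyl in place of hydrogen on an aromatic carbon). Within the data shown here, no measured pair shows such a change, so the expectation remains loose. The estimated step of a 1.1-fold lower number from compound 2 to compound 3 (0.05 log units; within the scatter) is expected to stay within the scatter, with no firm direction. In this assay compound 3 is expected at 15000 nM with an estimated range from 6500 nM to 35000 nM as a working figure.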

Compound 3, half-maximal inhibitory concentration: 27500 nM
Beside the measured number, compound 3's estimate is 1.8-fold (0.26 log units) below it, within the range that was stated.
By their numbers in this assay, from the lowest: compounds 1, 2 and 3 (each within the scatter of the next).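

Among these compounds, on an aromatic carbon, para to a large group, methyl in place of hydrogen gives a 1.6-fold higher number from compound 2 to compound 3 (0.21 log units; within the scatter), the first single-place step. In this assay, this single step does not separate the change from repeat-measurement variation, and no direction can be assigned to it. Nothing measured alongside it bears on this result. Still open, on these data alone, is whether an amine or a carboxylic acid on the same aromatic carbon would give a step beyond the scatter.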